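Cyclohexyl in Place of sec-Butyl on an Amine Nitrogen

The source may hold more compounds than are shown below. What is called first, only, known or untested is meant among the compounds shown, and "the series" means these compounds.

Compound 1 `COc1cc(/C=C/C(=O)/C=C(/C=C/c2ccc(OC(C)=O)c(OC)c2)NC2CCCCC2)ccc1OC(C)=O`: 113%
Compound 2 `CCC(C)NC(=C\C(=O)/C=C/c1ccc(O)cc1)/C=C/c1ccc(O)cc1`: 414%
Compound 3 `CCC(C)NC(=C\C(=O)/C=C/c1ccc(OC(C)=O)c(OC)c1)/C=C/c1ccc(OC(C)=O)c(OC)c1`: 105%

These three were run in a functional assay on EA.hy 926 cells (Homo sapiens), read by fluorescence, tested at 10 uM; a lower number here means a weaker effect, a higher number a stronger effect of the compound at the concentration tested. Compound 2 stands highest, well beyond the scatter from the other two, while the difference between the core of compound 2 and the core of compound 3 is not broken down here. Compound 1 and compound 3 differ in one place only, (cyclohexyl in place of sec-butyl on an amine nitrogen), and this gave a number 8 percentage points higher from compound 3 to compound 1 (within the scatter).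

Compound 4 `O=C(/C=C(/C=C/c1ccc(O)cc1)NC1CCCCC1)/C=C/c1ccc(O)cc1` carries the same change relative to compound 2: cyclohexyl in place of sec-butyl on an amine nitrogen. Because the measured version of this change, a number 8 percentage points higher from compound 3 to compound 1 (within the scatter), stayed within the scatter, the expected step to compound 4 is also small, no change at the digits printed from compound 2 to compound 4 (within the scatter). Compound 4 is therefore estimated to reach 414%, between 320% and 510%.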

Compound 4, a percentage reported as activity, at one concentration (the size of the read-out at that concentration, not a potency): 299%
Estimate against measurement, compound 4: 115 percentage points above; the measured number lies below the stated range.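

In this assay, putting cyclohexyl in place of sec-butyl on the amine nitrogen gave a number 115 percentage points lower from compound 2 to compound 4 (beyond the scatter), so the result of this change on one core did not predict its result on the other. Set side by side, the two steps show that the same change behaved differently on the two cores: the same change on two cores in this assay, a number 8 percentage points higher (within the scatter) from compound 3 to compound 1 and a number 115 percentage points lower (beyond the scatter) from compound 2 to compound 4, 123 percentage points apart, beyond the scatter of two such steps. They do not show which difference between the cores is responsible, and two cores give no general rule for the series.

The compounds shown leave open how a small group such as methyl or a longer chain such as n-hexyl on the same nitrogen would behave on each core. As far as these compounds go, a core carrying both free hydroxyl and methoxy groups also remains open, and it could help separate the contributions of those core features.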